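A few compounds are considered here, and "the series" means these few. Any claim that something is new, unique, unknown or untested is made for them only; others in the source may bear on it.

Of the compounds shown here, three built on one shared core have been tested in a functional assay on SMMC-7721 cells (Homo sapiens) for antiproliferative activity, read by CCK-8 assay, with a stated time of 48 h; a lower number here means a stronger inhibitor, a higher number a weaker inhibitor. Compound 1 `O=c1c2ccccc2[se]n1-c1nc(SCc2ccccc2)n[nH]1` gives 32000 nM. Compound 2 `Cc1ccccc1CSc1n[nH]c(-n2[se]c3ccccc3c2=O)n1` gives 36200 nM in this assay. Compound 3 `CCCCCCSc1n[nH]c(-n2[se]c3ccccc3c2=O)n1` gives 22400 nM in this assay. Compound 3 stands at the low end of these three numbers, yet neither other compound separates from it: a 1.4-fold lower number from compound 1 to compound 3 (0.15 log units; within the scatter), and a 1.6-fold lower number from compound 2 to compound 3 (0.21 log units; within the scatter). The first two differ only at an aromatic carbon: a 1.1-fold higher number from compound 1 to compound 2 (0.05 log units; within the scatter).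

Compound 4 `Cc1cccc(CSc2n[nH]c(-n3[se]c4ccccc4c3=O)n2)c1` has not yet been measured. Relative to compound 3 the change is 3-methylphenyl in place of pentyl on a saturated chain carbon bound to a sulfur. Going by the values given here, two measured steps bear directly on it, since each exchanges pentyl for an aromatic group on the same chain carbon, only in the opposite direction: a 1.4-fold lower number from compound 1 to compound 3 (0.15 log units; within the scatter), and a 1.6-fold lower number from compound 2 to compound 3 (0.21 log units; within the scatter), both within the scatter. A methyl added to that ring, judged from a 1.1-fold higher number from compound 1 to compound 2 (0.05 log units; within the scatter), also moved nothing beyond the scatter. The step into compound 4 is therefore expected to be a 1.3-fold higher number from compound 3 to compound 4 (0.13 log units; within the scatter), no change beyond the scatter in this assay, with a somewhat higher number if anything. Compound 4 is estimated at 30000 nM, with a range from 15000 nM to 60000 nM.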

Compound 4, half-maximal inhibitory concentration: 9040 nM
For compound 4 the middle estimate is 3.3-fold (0.52 log units) above the measured one; the measured number lies below the stated range.
By their numbers in this assay, from the lowest: compound 4; then compounds 3, 1 and 2 (each within the scatter of the next).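

In this assay the place on a saturated chain carbon bound to a sulfur, which had shown no step beyond the scatter among the earlier compounds, now responds: 3-methylphenyl in place of pentyl gives a 2.5-fold lower number from compound 3 to compound 4 (0.39 log units; beyond the scatter), and compound 4 stands beyond the scatter of all three others. The response belongs to this particular group and not to an aromatic ring as such: phenyl and 2-methylphenyl stay within the scatter of pentyl, yet 3-methylphenyl in place of 2-methylphenyl gives a 4.0-fold lower number from compound 2 to compound 4 (0.60 log units; beyond the scatter), and a methyl in place of hydrogen on an aromatic carbon gives a 3.5-fold lower number from compound 1 to compound 4 (0.55 log units; beyond the scatter), although the methyl that leads to compound 2 moved nothing beyond the scatter. Nothing available here accounts for this difference between the two methyl-bearing rings.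

The compounds shown leave open whether 4-methylphenyl would follow 3-methylphenyl or 2-methylphenyl, and whether an ethyl or a chlorine on the ring would serve as the methyl does. They also leave open how far the number can fall at this place, since only a modest step is seen so far.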